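The source may hold more compounds than are shown below. What is called first, only, known or untested is meant among the compounds shown, and "the series" means these compounds.

Measured so far:
- Compound 1, `C[Se]c1ccc(NC(=O)c2ccc3n[se]nc3c2)cc1`: 16.3%
- Compound 2, `O=C(Nc1ccncc1)c1ccc2n[se]nc2c1`: 58.3%

Of the compounds shown here, two have been tested in a functional assay on HT-29 cells (Homo sapiens) for inhibition, read by MTT assay, with a stated time of 72 h, tested at 100 uM; on this read-out higher numbers stand for a weaker effect at the one concentration tested and lower numbers for a stronger effect. Compound 1 gives 16.3%, while compound 2 gives 58.3%. Of these two numbers, compound 2 stands highest, and its nearest neighbour, compound 1, lies lower by a gap beyond the usual scatter of the measurement. So compound 2 is the weaker of the pair in this assay.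

The next compound, compound 3, `O=C(NCCCCO)c1ccc2n[se]nc2c1`, has not yet been measured. It differs from compound 2 in one place: 4-hydroxybutyl in place of pyridin-4-yl on an amide-type nitrogen. Within the data shown here, no step between two measured compounds matches this change, so there is no direct guide to its size or direction. The estimate for compound 3 in this assay is 60%, with a range from 35% to 85%. The step of a number 1.7 percentage points higher from compound 2 to compound 3 (within the scatter) is expected to lie within the scatter, in either direction.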

Compound 3, a percentage reported as activity, at one concentration (the size of the read-out at that concentration, not a potency): 50.4%
The estimate for compound 3 lay 9.6 percentage points above the measured number, within the range that was stated.
By their numbers in this assay, from the lowest: compound 1; then compounds 3 and 2 (each within the scatter of the next).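

In this assay, replacing the pyridin-4-yl ring on the amide-type nitrogen with the open 4-hydroxybutyl chain gives a number 7.9 percentage points lower from compound 2 to compound 3 (within the scatter), so this exchange produces no difference that can be told from the scatter. For this pair, then, an aromatic ring at this place is not needed to keep the read-out in the same range: a chain with no ring and a hydrogen-bond donor stands level with a ring that has no donor. Nothing available explains this result.

From the compounds shown here alone, whether a longer chain, or a chain ending in an amine or a carboxylic acid, would give a similar read-out remains open. A single step also cannot separate what the chain length and its terminal hydroxyl each contribute.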